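Swapping the nitrile of compound 3 for sulfamoylmethyl

This account rests on a few compounds, and the source may have more. Where it says the series, first, only, none or still open, it means among the compounds named here.

Compound 1 `N#Cc1ccc(S(=O)(=O)Nc2cccc3cc[nH]c23)cc1` gives 8.5 ug/mL
Compound 2 `N#Cc1ccc(S(=O)(=O)Nc2cccc3c(C#N)c[nH]c23)cc1` gives 33 ug/mL
Compound 3 `N#Cc1ccc(S(=O)(=O)Nc2cccc3c(Cl)c[nH]c23)cc1` gives 11 ug/mL

All three values come from a functional assay on KB cells (nasopharynx, Homo sapiens) for antiproliferative activity (on this read-out higher numbers stand for weaker inhibition and lower numbers for stronger inhibition), and all three compounds carry the cyano group. Compound 3 at 11 ug/mL sits within the scatter of compound 1 and clear of compound 2, with a 3.0-fold lower number from compound 2 to compound 3 (0.48 log units; beyond the scatter) on record.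

Next comes compound 4 `NS(=O)(=O)Cc1ccc(S(=O)(=O)Nc2cccc3c(Cl)c[nH]c23)cc1` which differs from compound 3 by a single change (sulfamoylmethyl in place of cyano on an aromatic carbon).

For the measured compounds named here, no measured step touches that place. The nearest evidence lies at a different aromatic carbon: a 3.9-fold higher number from compound 1 to compound 2 (0.59 log units; beyond the scatter) and a 1.3-fold higher number from compound 1 to compound 3 (0.11 log units; within the scatter) show the size of change seen so far in the series. They give no direction for the new group. A modest step toward a lower number in this assay is expected, but this is a judgement the measured steps do not settle, and the opposite direction cannot be excluded. The expected step is a 3.7-fold lower number from compound 3 to compound 4 (0.56 log units; beyond the scatter) with wide uncertainty. For compound 4 the estimated value is 3 ug/mL within an expected range of 0.4 ug/mL to 15 ug/mL in this read-out.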

Compound 4, half-maximal inhibitory concentration: 13 ug/mL
Compound 4: the middle estimate sits 4.3-fold (0.64 log units) below what was measured, within the range that was stated.
By their numbers in this assay, from the lowest: compounds 1, 3 and 4 (each within the scatter of the next); then compound 2.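

Cyano and sulfamoylmethyl, on an aromatic carbon para to a large group, give values within the scatter of each other in this assay (a 1.2-fold higher number from compound 3 to compound 4 (0.07 log units; within the scatter)). The earlier compounds shown here all carried the cyano group, so they showed nothing about this place; it now appears that a group of 5 heavy atoms, with 1 hydrogen-bond donor where cyano has none, can stand there without a step beyond the scatter in this read-out, whereas the cyano in place of hydrogen at the other aromatic carbon gave a step beyond it (a 3.9-fold higher number from compound 1 to compound 2 (0.59 log units; beyond the scatter)). No evidence is available to account for this result.

Going by these compounds, compound 4 and compound 3 both carry the chloro group, so it remains open whether sulfamoylmethyl would read the same way on the core of compound 1 or of compound 2. Also open, on these data alone, is whether this place stays as permissive for an amine, a carboxylic acid or a longer chain, or whether one of these would move the number beyond the scatter in either direction.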